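The compounds below may be only part of what the source reports. "The series", "measured", "known", "first", "only" and "open" are said of these compounds alone.

Compound 1 `CC1CCN(C(=O)CN(C)C(=O)c2ccc(S(C)(=O)=O)c([N+](=O)[O-])c2)CC1`: in an ADME assay on HepG2 cells (Homo sapiens) for cytotoxicity, read by CellTiter-Glo and ATP content, with a stated time of 72 h (on this read-out higher numbers stand for an effect only at larger amounts of compound and lower numbers for an effect already at smaller amounts), compound 1 reaches only the limit > 27000 nM, which is a limit of the assay and not a number.
Compound 2 `CS(=O)(=O)c1ccc(C(=O)N2CCC(C(=O)N(Cc3ccccc3)Cc3ccccc3)CC2)cc1[N+](=O)[O-]`: in this assay compound 2 likewise reaches only the limit > 27000 nM.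
Compound 3 `CC1CCN(C(=O)CCNC(=O)c2ccc(S(C)(=O)=O)c([N+](=O)[O-])c2)CC1`: in this assay compound 3 also reaches only the limit > 27000 nM.

Compound 1 therefore stands where every measured compound in this set stands: at a limit rather than at a number. Among the measured compounds shown here, since no compound gives a number, nothing can be said about the order of the three, and no step between measured compounds is available to show how large a change of this kind can be.

Compound 4 `CN(CC(=O)N1CCc2ccccc2C1)C(=O)c1ccc(S(C)(=O)=O)c([N+](=O)[O-])c1` has not yet been measured. Set beside compound 1, it shows (1,2,3,4-tetrahydroisoquinolin-2-yl in place of 4-methylpiperidin-1-yl on a carbonyl carbon). Without a measured step of comparable kind, the expected size of the step from compound 1 to compound 4 in this assay is none beyond the scatter, because the limit of > 27000 nM in this assay, at which 3 of the 3 values shown sit, leaves no room in the data for any movement in either direction. On that basis compound 4 is expected to give 40000 nM, in a range from 15000 nM to 120000 nM, most likely reported again only as a limit; the expected step is a step that the limit leaves unreadable from compound 1 to compound 4.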

Compound 4, half-maximal effective concentration: > 27000 nM
Compound 4 ended at the assay's limit; the forecaster's own chance of this, stated with the estimate: 80%; the middle value is on the limit's open side.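

No new step can be read from compound 1 to compound 4, because in this assay both results are limits of the assay and not numbers: the limit of > 27000 nM in this assay, at which 4 of the 4 values shown sit.

The compounds shown leave open at what amount any of them would affect these cells, and whether 1,2,3,4-tetrahydroisoquinolin-2-yl in place of 4-methylpiperidin-1-yl changes that amount at all.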